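The source may hold more compounds than are shown below. What is called first, only, known or untested is meant among the compounds shown, and "the series" means these compounds.

Compound 1 `O[C@@H](c1ccccc1)[C@H]1CO[C@H](c2ccccc2)[C@@H](C/C=C/c2ccncc2)C1`: > 100000 nM, a limit of the assay, not a number.
Compound 2 `COc1ccc(/C=C/C[C@@H]2C[C@@H]([C@@H](O)c3ccc(OC)c(OC)c3)CO[C@H]2c2ccc(OC)c(OC)c2)cc1OC`: 30600 nM
Compound 3 `COc1ccc([C@H]2OC[C@H]([C@@H](O)c3ccc(OC)c(OC)c3)C[C@@H]2C/C=C/c2ccccc2)cc1OC`: 14800 nM

Of the compounds shown here, three sharing one core have been tested in a functional assay on HeLa cells (Homo sapiens) for cytotoxicity, read by WST assay, with a stated time of 48 h; a lower number here means a stronger inhibitor, a higher number a weaker inhibitor. Compound 1 stands apart from the other two: in this assay compound 1 gives only > 100000 nM, which is a limit of the assay rather than a measured number (the limit of > 100000 nM in this assay, at which 1 of the 3 values shown sits). Compound 2 and compound 3, which carry extra groups on their aromatic rings, give measured numbers in this assay, with compound 3 at 14800 nM and compound 2 at 30600 nM.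

The next compound, compound 4 `O=[N+]([O-])c1cccc(/C=C/C[C@H]2C[C@@H]([C@@H](O)c3ccccc3)CO[C@@H]2c2ccccc2)c1`, keeps the unsubstituted core of compound 1 and changes only the ring at the end of the chain: 3-nitrophenyl in place of pyridin-4-yl on a double-bonded chain carbon bound to a double-bonded chain carbon.

Going by the values given here, no pair of measured compounds differs in just one place, so there is no measured step to lean on. Because compound 1 sits at a limit (the limit of > 100000 nM in this assay, at which 1 of the 3 values shown sits), any direction the change takes cannot be read off the numbers shown; the step from compound 1 is expected to be modest and is as likely to stay within the scatter as to go beyond it, so the step of an at least 2.0-fold lower number from compound 1 to compound 4 (0.30 log units; that floor lies within the scatter) is expected to be small. Compound 4 is estimated at 50000 nM, expected to lie between 12000 nM and 150000 nM.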

Compound 4, half-maximal inhibitory concentration: 7850 nM
Compound 4: middle estimate off by 6.4-fold (0.80 log units), on the high side, and the stated range ends above it.
By their numbers in this assay, from the lowest: compounds 4 and 3 (each within the scatter of the next); then compound 2. At a limit, above all of these: compound 1.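

Going by these compounds alone, replacing pyridin-4-yl with 3-nitrophenyl on a double-bonded chain carbon bound to a double-bonded chain carbon gives an at least 12-fold lower number from compound 1 to compound 4 (1.10 log units; beyond the scatter) in this assay, the first single-place comparison in this set, and it shows that the ring at the end of the chain matters at this position. On the core of compound 1, this one change is enough to turn a result at the assay's limit into a measured number, with the other two rings left unsubstituted. In this assay, compound 1 gives > 100000 nM, which is a limit of the assay and not a number, and the true size of the step stays unknown because the step can only be stated as a minimum: the limit of > 100000 nM in this assay, at which 1 of the 4 values shown sits.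

The change removes the ring nitrogen and brings in the nitro group at the same time, and the compounds shown cannot tell which of the two accounts for the step. As far as these compounds go, it also remains open how this position would respond to an amine or a carboxylic acid in place of the nitro group, or to a plain phenyl ring on the unsubstituted core.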